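A few compounds are considered here, and "the series" means these few. Any claim that something is new, unique, unknown or untested is made for them only; others in the source may bear on it.

Compound 1 `COc1ccc(-c2[nH]c3ccccc3c2/C=C(\C#N)S(=O)(=O)c2ccccc2)cc1` is the starting point. In a functional assay on SK-MEL-2 cells (Homo sapiens) for inhibition, read by sulforhodamine B assay, with a stated time of 48 h (on this read-out lower numbers stand for stronger inhibition of growth and higher numbers for weaker inhibition of growth), compound 1 gives 18100 nM. Compound 3 `COc1ccc(-c2[nH]c3ccc(OC)cc3c2/C=C(\C#N)S(=O)(=O)c2ccccc2)cc1` carries one change on the shared core, (methoxy in place of hydrogen on an aromatic carbon), and in this assay compound 3 gives 9000 nM, so that the change made a 2.0-fold lower number from compound 1 to compound 3 (0.30 log units; within the scatter).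

Compound 2 `COc1ccc2[nH]c(-c3ccccc3)c(C=C(C#N)C#N)c2c1` is built on a different core; how its core differs from that of compound 1 is not broken down here. In this assay compound 2 gives 5900 nM.

Compound 4 `COc1ccc(-c2[nH]c3ccc(OC)cc3c2C=C(C#N)C#N)cc1` is not yet measured. It differs from compound 2 by methoxy in place of hydrogen on an aromatic carbon. Among the compounds with values here, this is the same kind of change as the one from compound 1 to compound 3, not the same: there the methoxy entered on a ring that is part of a fused or bridged system of two rings, meta to a fused ring and para to a fused ring, while here it enters para to a large group.

Because a 2.0-fold lower number from compound 1 to compound 3 (0.30 log units; within the scatter) was small, a step of about a 1.5-fold lower number from compound 2 to compound 4 (0.17 log units; within the scatter) is expected. Compound 4 is therefore estimated at 4000 nM, with a range from 1500 nM to 12000 nM.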

Compound 4, concentration for 50% growth inhibition: 5900 nM
Compound 4: middle estimate off by 1.5-fold (0.17 log units), on the low side, within the range that was stated.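

In this assay, placing the methoxy on the core of compound 2 gives no change at the digits printed from compound 2 to compound 4 (within the scatter). Set beside the earlier step, the result does not separate the two cores: the same change on two cores in this assay, a 2.0-fold lower number (0.30 log units; within the scatter) from compound 1 to compound 3 and no change at the digits printed (within the scatter) from compound 2 to compound 4, 2.0-fold (0.30 log units) apart, within the scatter of two such steps

This shows that, in these two pairs, the change carries from one core to the other in a limited sense: on neither core does it move the number beyond the scatter. It does not show that the methoxy has no effect or exactly the same effect on both cores, since two small steps cannot settle that and the methoxy does not enter at the same place in each.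

The compounds shown leave open whether an amine, a carboxylic acid or a longer chain in place of the methoxy would give a step beyond the scatter. They also leave open whether the same small steps would appear in other cell lines, since these comparisons come from one assay only.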